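Hydroxyphenyl and thiophenyl swaps on a pyridine-type core

This account rests on a few compounds, and the source may have more. Where it says the series, first, only, none or still open, it means among the compounds named here.

Measured so far in a functional assay on DU-145 cells (Homo sapiens) for cytotoxicity, read by CCK-8 assay; a higher number here means a weaker inhibitor, a lower number a stronger inhibitor:
- compound 1 `Oc1cccc(-c2cc(-c3cccs3)cc(-c3ccccc3O)n2)c1`: compound 1 gives 9300 nM
- compound 2 `Oc1ccc(-c2cc(-c3cccs3)cc(-c3ccccc3O)n2)cc1`: for compound 2 the assay reports only a limit, > 50000 nM
- compound 3 `Oc1cccc(-c2cc(-c3ccsc3)cc(-c3ccccc3O)n2)c1`: for compound 3 the assay reports only a limit, > 50000 nM

Among the compounds with values here, compound 1 is the only member with a number rather than a limit. The change from compound 1 to compound 2, (4-hydroxyphenyl in place of 3-hydroxyphenyl on an aromatic carbon), gives an at least 5.3-fold higher number from compound 1 to compound 2 (0.73 log units; beyond the scatter). The change from compound 1 to compound 3, (thiophen-3-yl in place of thiophen-2-yl on an aromatic carbon), gives an at least 5.3-fold higher number from compound 1 to compound 3 (0.73 log units; beyond the scatter). Both values at the limit stem from the limit of > 50000 nM in this assay, at which 2 of the 3 values shown sit, so the true size of either step is open.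

Compound 4 `Oc1ccc(-c2cc(-c3ccsc3)cc(-c3ccccc3O)n2)cc1` is not yet measured. It differs from compound 3 by 4-hydroxyphenyl in place of 3-hydroxyphenyl on an aromatic carbon, the same kind of change as that from compound 1 to compound 2; the surroundings differ in that the place is meta to a thiophen-3-yl group in compound 3, and meta to a thiophen-2-yl group in compound 1. The cores of compound 3 and compound 1 differ by thiophen-3-yl in place of thiophen-2-yl on an aromatic carbon.

The expected step is a step that the limit leaves unreadable from compound 3 to compound 4, resting on the earlier at least 5.3-fold higher number from compound 1 to compound 2 (0.73 log units; beyond the scatter) and on compound 3 already sitting at the limit. Compound 4 is expected at about 100000 nM in this assay, estimated between 40000 nM and 300000 nM, most likely again reported only as a limit.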

Compound 4, half-maximal inhibitory concentration: > 50000 nM
Compound 4: only a limit was reported; the forecaster's own chance of this, stated with the estimate: 90%; the middle value is on the limit's open side.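

Compound 2, compound 3 and compound 4 are all reported only as limits in this assay, so no step can be read from compound 3 to compound 4 or from compound 2 to compound 4: the limit of > 50000 nM in this assay, at which 3 of the 4 values shown sit.

The compounds shown leave open how these three compare with one another, and whether 4-hydroxyphenyl in place of 3-hydroxyphenyl has the same effect with thiophen-3-yl as with thiophen-2-yl.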